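Swapping the Pyridine Ring of Compound 3 for Phenyl

This account rests on a few compounds, and the source may have more. Where it says the series, first, only, none or still open, it means among the compounds named here.

Compound 3 `N=C(NCCCc1c[nH]cn1)NCCC(c1ccc(Cl)c(Cl)c1)c1ccccn1` gives 7.54 in a functional assay on muscle tissue for agonist activity at histamine H2 receptor (Cavia porcellus); a higher number here means a more potent compound, by a factor of ten per unit of this negative logarithm, a lower number a less potent compound. Among the three measured compounds it stands second highest: compound 1 `N=C(NCCCc1c[nH]cn1)NCCC(c1ccccc1)c1ccccn1` gives 7.37, and a number 0.17 log units higher from compound 1 to compound 3 (within the scatter) is within the scatter, while compound 2 `N=C(NCCCc1c[nH]cn1)NCCC(c1cc(F)cc(F)c1)c1ccccn1` gives 7.91 and a number 0.37 log units lower from compound 2 to compound 3 (beyond the scatter). Compound 4 `N=C(NCCCc1c[nH]cn1)NCCC(c1ccccc1)c1ccc(Cl)c(Cl)c1` differs from compound 3 by phenyl in place of pyridin-2-yl on a saturated chain carbon bound to an aromatic carbon and a saturated chain carbon. Among the measured compounds shown here, none of the measured steps touches this ring: a number 0.54 log units higher from compound 1 to compound 2 (beyond the scatter) and the other two steps all vary the other aromatic ring on the same chain carbon. With nothing to anchor it, the direction is uncertain, and a moderate loss is expected, a number 0.84 log units lower from compound 3 to compound 4 (beyond the scatter). Compound 4 is therefore estimated at 6.7, with a range from 5.8 to 7.6.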

Compound 4, negative logarithm of the half-maximal effective concentration: 6.03
Compound 4: middle estimate off by 0.67 log units, on the high side; the measured number falls inside the stated range.
By their numbers in this assay, from the lowest: compound 4; then compounds 1 and 3 (each within the scatter of the next); then compound 2.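

Among the compounds shown here, the pyridin-2-yl ring on this chain carbon carries far more weight than the other aromatic ring did in the earlier steps: with phenyl in its place, the result is a number 1.51 log units lower from compound 3 to compound 4 (beyond the scatter). Replacing it with 3,4-dichlorophenyl also gives a large fall, a number 1.34 log units lower from compound 1 to compound 4 (beyond the scatter), so both replacements, each without the ring nitrogen, lower the number. Nothing available explains this fall. Still open, on these data alone, is whether pyridin-3-yl or pyridin-4-yl, with the nitrogen elsewhere in the ring, would keep the number of compound 3. A simple amine on the same carbon is equally untested here.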